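Hydrogen in place of methyl on a thio-sugar nucleoside core

This account rests on a few compounds, and the source may have more. Where it says the series, first, only, none or still open, it means among the compounds named here.

Compound 1 `Cc1cn([C@@H]2SC[C@@](C)(O)[C@H]2O)c(=O)[nH]c1=O` — 41000 nM
Compound 2 `Cc1cn([C@H]2SC[C@](C)(O)[C@@H]2O)c(=O)[nH]c1=O` — 30000 nM

In a functional assay on A549 cells (Homo sapiens) for cytotoxicity, read by MTT assay, with a stated time of 48 h (a lower number here means a stronger inhibitor, a higher number a weaker inhibitor), compound 2 gives 30000 nM and compound 1 gives 41000 nM; these two numbers sit within the scatter of each other, as a 1.4-fold lower number from compound 1 to compound 2 (0.14 log units; within the scatter) shows, and that step rests only on (the fact that compounds 1 and 2 differ only in the configuration as drawn). Compound 3 `C[C@]1(O)CS[C@H](n2ccc(=O)[nH]c2=O)[C@H]1O` differs from compound 2 by hydrogen in place of methyl on an aromatic carbon. Going by the values given here, no measured step touches this position, so no size of step is indicated, and none beyond the scatter is expected in this assay. Compound 3 is therefore estimated at 35000 nM, between 12000 nM and 100000 nM, which is expected to mean a 1.2-fold higher number from compound 2 to compound 3 (0.07 log units; within the scatter).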

Compound 3, half-maximal inhibitory concentration: 30000 nM
Beside the measured number, compound 3's estimate is 1.2-fold (0.07 log units) above it, within the range that was stated.
By their numbers in this assay, from the lowest: compounds 2, 3 and 1 (each within the scatter of the next).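

Going by these compounds alone, replacing methyl with hydrogen on the aromatic carbon is the first measured step at this position, and in this assay it gives no change at the digits printed from compound 2 to compound 3 (within the scatter). The earlier pair spoke only to configuration, whereas this step shows that the methyl can be lost here without a step beyond the scatter. Nothing given here bears on the reason for this outcome. The compounds shown leave open whether a fluorine atom, an amine or a longer chain at this position would move the number beyond the scatter. They also leave open how the same change reads on the mirror-image core of compound 1.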